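Trifluoromethoxy in place of carbamoyl on compound 2

The source may hold more compounds than are shown below. What is called first, only, known or untested is meant among the compounds shown, and "the series" means these compounds.

Going by the values given here, in a physicochemical assay for solubility, at pH 7.4 (on this read-out higher numbers stand for higher solubility and lower numbers for lower solubility), compound 2 `Cc1cc(NC(=O)Nc2ccc(C(N)=O)cc2)c2ccccc2n1` gives 900 nM and holds the lower of the two numbers so far, while compound 1 `CC(=O)c1ccc(NC(=O)Nc2cc(C)nc3ccccc23)cc1` gives 3800 nM on the same read-out.

The next compound, compound 3 `Cc1cc(NC(=O)Nc2ccc(OC(F)(F)F)cc2)c2ccccc2n1`, has trifluoromethoxy in place of carbamoyl on an aromatic carbon, para to a large group trifluoromethoxy in place of carbamoyl on an aromatic carbon and is otherwise the same as compound 2.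

Among the compounds with values here, one measured step bears on this, and only indirectly. With amino in place of methyl on a carbonyl carbon, a 4.2-fold lower number from compound 1 to compound 2 (0.63 log units; beyond the scatter) is modest and beyond the scatter, and it touches the same substituent. Within the data shown here, no measured compound carries trifluoromethoxy, so the data give neither the direction nor the size directly. The direction here is a judgement: a modest fall is expected rather than a rise, of about the size of the measured step, and a result close to compound 2 would not be surprising.

The estimated change is a 2.3-fold lower number from compound 2 to compound 3 (0.35 log units; beyond the scatter) in this assay on this reasoning. Compound 3 is expected at 400 nM with an estimated range from 100 nM to 1600 nM for now.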

Compound 3, solubility: 300 nM
The estimate for compound 3 lay 1.3-fold (0.12 log units) above the measured number, within the range that was stated.
By their numbers in this assay, from the lowest: compound 3; then compound 2; then compound 1.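

At this aromatic carbon, para to a large group, this assay now spans three substituents on an otherwise unchanged structure, and carbamoyl no longer marks the low end: a 3.0-fold lower number from compound 2 to compound 3 (0.48 log units; beyond the scatter), a modest step beyond the scatter. Set against acetyl, trifluoromethoxy gives the largest change in the series so far, a 13-fold lower number from compound 1 to compound 3 (1.10 log units; beyond the scatter), which shows that this one position alone can move the number by a large amount, with acetyl highest, carbamoyl in the middle and trifluoromethoxy lowest among these three compounds. No measurement on hand accounts for this order. The counts do show that the hydrogen-bond donor of carbamoyl is absent from trifluoromethoxy.

On these data alone, three substituents fix an order but not a trend, and it remains open where a carboxylic acid, a dimethylamino group or a nitrile at this position would fall relative to acetyl and trifluoromethoxy. As far as these compounds go, it is also open whether the steps at this position would keep their size and direction with a change elsewhere on the shared core.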